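The source may hold more compounds than are shown below. What is called first, only, known or untested is meant among the compounds shown, and "the series" means these compounds.

Compound 1 `CCNC(=O)c1cc(C(=O)NC)c(=O)n(Cc2ccccc2)c1` gives >= 144 ug/mL in a physicochemical assay for solubility (a lower number here means a less soluble compound, a higher number a more soluble compound), which is a limit of the assay rather than a number. Compound 2 `CNC(=O)c1cc(C(=O)NC2CC2)cn([C@H](C)c2ccccc2)c1=O` gives >= 168 ug/mL, again a limit. Compound 3 `CNC(=O)c1cc(C(=O)NC2CCC2)cn(Cc2cccc(NC)c2)c1=O` gives >= 155 ug/mL, also a limit.

Compound 1 therefore stands at a limit, (the limit of >= 144 ug/mL in this assay, at which 1 of the 3 values shown sits), and since every value shown is a limit, no ordering among the three can be drawn from them. Compound 4 `CNC(=O)c1cc(C(=O)NCCC(C)C)cn(Cc2ccccc2)c1=O` differs from compound 1 in one place: isopropyl in place of hydrogen on a saturated chain carbon, two bonds along the chain from an amide-type nitrogen. For the measured compounds named here, no measured pair shows what such a change does in this assay, so the expectation rests on the structures alone: the step of an at least 1.6-fold lower number from compound 1 to compound 4 (0.20 log units; that floor lies within the scatter) is expected to run downward, by an amount that may just exceed the usual scatter. Compound 4 is accordingly estimated at 90 ug/mL, within 35 ug/mL to 200 ug/mL, with a fair chance that it too is reported only as a limit.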

Compound 4, solubility: 10 ug/mL
Compound 4: the middle estimate sits 9.0-fold (0.95 log units) above what was measured; the measured number lies below the stated range.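

For the compounds shown here, at this place, on a saturated chain carbon, two bonds along the chain from an amide-type nitrogen, isopropyl in place of hydrogen gives the first step that can be read in this assay, an at least 14-fold lower number from compound 1 to compound 4 (1.15 log units; beyond the scatter). Going by these compounds alone, compound 4 is also the first compound here with a number rather than a limit, so a change at this position can move the read-out well beyond the scatter. From the compounds shown here alone, the full size of the step stays unknown because compound 1 stands at a limit: the limit of >= 144 ug/mL in this assay, at which 1 of the 4 values shown sits.

Going by these compounds, whether an amine, a hydroxyl or a carboxylic acid in place of isopropyl would give a higher number stays open. Also open, on these data alone, is how a chain between ethyl and isopentyl in length, such as propyl, would read.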